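From Phenyl to Butyl on the Triple Bond: Compound 4

A few compounds are considered here, and "the series" means these few. Any claim that something is new, unique, unknown or untested is made for them only; others in the source may bear on it.

Measured compounds:
Compound 1, `O=c1[nH]c(=O)n([C@H]2C[C@H](O)[C@@H](CO)O2)cc1C#CCO`, gives in an ADME assay on L1210/0 cells (Mus musculus) for cytotoxicity, with a stated time of 48 h (on this read-out higher numbers stand for weaker inhibition and lower numbers for stronger inhibition), the limit > 200000 nM.
Compound 2, `CCCC#Cc1cn([C@H]2C[C@H](O)[C@@H](CO)O2)c(=O)[nH]c1=O`, gives in this assay the limit > 200000 nM.
Compound 3, `O=c1[nH]c(=O)n([C@H]2C[C@H](O)[C@@H](CO)O2)cc1C#Cc1ccccc1`, gives in this assay the limit > 200000 nM.

Each of these values is a limit of the assay rather than a number; all three sit at the limit of > 200000 nM in this assay, at which 3 of the 3 values shown sit. Compound 3 therefore stands nowhere distinct on the numbers shown: its value is a limit, and the two other values are limits as well. The steps among the measured compounds are accordingly unreadable: a step that the two limits leave unreadable from compound 1 to compound 2, a step that the two limits leave unreadable from compound 1 to compound 3 and a step that the two limits leave unreadable from compound 2 to compound 3. None of them gives a size or a direction.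

Compound 4, `CCCCC#Cc1cn([C@H]2C[C@H](O)[C@@H](CO)O2)c(=O)[nH]c1=O`, differs from compound 3 by butyl in place of phenyl on a triple-bonded carbon. Among the measured compounds shown here, the steps that bear on this change are the three unreadable ones, since each also exchanges a group on the triple-bonded carbon. Compound 2, carrying propyl there, and compound 3, carrying phenyl, both return limits, so in this assay no step beyond the scatter is expected from this exchange, and compound 4 is most likely to return a limit again. Compound 4 is therefore estimated at 200000 nM, with a range from 100000 nM to 400000 nM. This estimate implies the expected step of a number no higher from compound 3 to compound 4 (the limit leaves the size open), within the scatter.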

Compound 4, half-maximal inhibitory concentration: > 200000 nM
Compound 4 ended at the assay's limit (the forecaster's own chance of this, stated with the estimate: 85%); the middle value sits exactly at the limit.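

The steps from compound 1, compound 2 and compound 3 to compound 4 cannot be read, and the result adds neither a size nor a direction: the limit of > 200000 nM in this assay, at which 4 of the 4 values shown sit. The compounds shown leave open which group on the triple-bonded carbon, if any, would give in this assay a number rather than a limit.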